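The compounds below may be only part of what the source reports. "The series", "measured", "known", "first", "only" and "open" are said of these compounds alone.

Compound 1, `Nc1nn(C(=O)Nc2ccc(Cc3ccccc3)cc2)c2ccccc12`, and compound 2, `Nc1nn(C(=O)Nc2ccc(Cc3ccccc3)cc2)c2ccc(Cl)cc12`, share one core; compound 2 differs only in carrying chloro in place of hydrogen on an aromatic carbon. In a functional assay on PC-3 cells (Homo sapiens) for antiproliferative activity, read by sulforhodamine B assay, with a stated time of 48 h (a higher number here means that more compound is tolerated, a lower number that less compound is tolerated), compound 1 gives > 100000 nM, which is a limit of the assay and not a number. In this assay compound 2 gives > 100000 nM, again a limit rather than a number. The step from compound 1 to compound 2 is accordingly a step that the two limits leave unreadable from compound 1 to compound 2. Where compound 2 stands is therefore known only as the limit of > 100000 nM in this assay, at which 2 of the 2 values shown sit. Compound 3, `Nc1ccc2c(c1)c(N)nn2C(=O)Nc1ccc(Cc2ccccc2)cc1`, is the next member of the set: amino in place of chloro on an aromatic carbon. Among the compounds with values here, the only measured step that bears on this change is the one from compound 1 to compound 2, and since both of its ends are limits, its size cannot be read, so it gives no direction for this assay. With nothing pointing elsewhere, the expected step is a number no higher from compound 2 to compound 3 (the limit leaves the size open), which is to say no change beyond the scatter. The estimate for compound 3 is 100000 nM, with a range from 30000 nM to 300000 nM, and it is expected that the assay will most likely again report only a limit.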

Compound 3, concentration lethal to 50% of the cells: 87000 nM
Estimate against measurement, compound 3: 1.1-fold (0.06 log units) above; measured number inside the range.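

With compound 3, the set gains its first value that is a number rather than a limit, so this position on the shared core now has one readable end in this assay. Amino in place of chloro gives an at least 1.1-fold lower number from compound 2 to compound 3 (0.06 log units; that floor lies within the scatter), and amino in place of hydrogen gives an at least 1.1-fold lower number from compound 1 to compound 3 (0.06 log units; that floor lies within the scatter); each of these is only a floor, as the other end of each step is a limit, so neither shows a change beyond the scatter and the true size of both stays unknown. The step between the two limits cannot be read, and the picture at this position is still dominated by a single boundary: the limit of > 100000 nM in this assay, at which 2 of the 3 values shown sit.

What the compounds shown leave open is whether any group on this aromatic carbon moves the number beyond the scatter, and whether a methoxy, a hydroxyl or an acetamide there would give a value that can be compared with that of compound 3 at both ends of the step. They also leave open whether a dimethylamino in place of the amino would keep a readable number in this assay.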